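A few compounds are considered here, and "the series" means these few. Any claim that something is new, unique, unknown or untested is made for them only; others in the source may bear on it.

Measured compounds:
- compound 1, `Nc1scc(CN2CCN(c3ccc([N+](=O)[O-])cc3)CC2)c1C(=O)c1ccc(Cl)cc1`, -8.3%
- compound 2, `Nc1scc(CN2CCC(c3ccc(Cl)cc3)CC2)c1C(=O)c1ccc(Cl)cc1`, -24%
- compound 3, `Nc1scc(CN2CCN(c3cccc(F)c3)CC2)c1C(=O)c1cccc(C(F)(F)F)c1`, -35%

These three compounds were tested in a functional assay on CHO cells with adenosine receptor A1 (Homo sapiens) as the target, read by cAMP accumulation and immunoassay, with a stated time of 6 min, tested at 1 uM; on this read-out higher numbers stand for a weaker effect at the one concentration tested and lower numbers for a stronger effect. Among them, compound 1 gives the highest number; compound 2 lies lower by more than the usual scatter, and compound 3 lies lower still, also by more than the scatter. Compound 4, `Nc1scc(CN2CCN(c3cccc4ccccc34)CC2)c1C(=O)c1ccc(Cl)cc1`, has not yet been measured in this assay. It differs from compound 1 in a single place: naphthalen-1-yl in place of 4-nitrophenyl on an amine nitrogen in a ring. Going by the values given here, no measured pair shows the effect of such a change, so only a cautious expectation is possible. Compound 4 is expected to give a number near that of compound 1, with a step of a number 5.7 percentage points lower from compound 1 to compound 4 (within the scatter) that probably stays within the scatter. The expected value for compound 4 is -14%, within a range from -40% to 12%.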

Compound 4, a percentage reported as activity, at one concentration (the size of the read-out at that concentration, not a potency): 2.9%
Estimate against measurement, compound 4: 16.9 percentage points below; measured number inside the range.
By their numbers in this assay, from the lowest: compound 3; then compound 2; then compound 1; then compound 4.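

In this assay, naphthalen-1-yl in place of 4-nitrophenyl on the amine nitrogen in the ring gives a number 11.2 percentage points higher from compound 1 to compound 4 (beyond the scatter). Going by these compounds alone, this is the first change in one place that can be read here, and it shows that the group at this position can shift the read-out, modestly, towards a weaker effect at the one concentration tested. Nothing available explains this step.

Still open, going by these compounds, is how a plain phenyl or a pyridine at this position would read. A single step also cannot show whether the shift would recur on another version of the core.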